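From isopropylsulfanyl to cyclopentylsulfanyl on the shared core

A few compounds are considered here, and "the series" means these few. Any claim that something is new, unique, unknown or untested is made for them only; others in the source may bear on it.

Within the data shown here, in an ADME assay on CCRF-HSB-2 cells (Homo sapiens) for cytotoxicity, with a stated time of 7 days (on this read-out higher numbers stand for lower toxicity in this test and lower numbers for higher toxicity in this test), compound 3 `CC(C)Sc1nc(N)nc2c1ncn2/C=C1/CC1(CO)CO` gives 94000 nM, the only true number so far. Compound 1 `CNc1nc(N)nc2c1ncn2/C=C1/CC1(CO)CO` gives > 20000 nM, which is a limit of the assay and not a number. Compound 2 `Nc1nc(OCC(F)(F)F)c2ncn(/C=C3/CC3(CO)CO)c2n1` gives > 20000 nM, again a limit. These two values make up (the limit of > 20000 nM in this assay, at which 2 of the 3 values shown sit).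

Compound 4 `Nc1nc(SC2CCCC2)c2ncn(/C=C3/CC3(CO)CO)c2n1` has cyclopentyl in place of isopropyl on a sulfur, so isopropylsulfanyl becomes cyclopentylsulfanyl: cyclopentyl in place of isopropyl on a sulfur.

Among the measured compounds shown here, no measured step covers this change directly. The nearest are a step that the limit leaves unreadable from compound 1 to compound 3 and a step that the limit leaves unreadable from compound 2 to compound 3, each of which introduces the isopropylsulfanyl group of compound 3. The remaining one, a step that the two limits leave unreadable from compound 1 to compound 2, involves neither sulfur compound. None of the three has a readable size, so the series gives no basis for a direction or size in this assay.

The expectation therefore stays anchored on compound 3 at 94000 nM, with a wide margin. A report of a limit alone would not be surprising. The expected move is a 1.3-fold lower number from compound 3 to compound 4 (0.13 log units; within the scatter), which is not expected to exceed the scatter. The estimate for compound 4 is 70000 nM, with an expected range of 25000 nM to 150000 nM.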

Compound 4, half-maximal cytotoxic concentration: 91000 nM
The estimate for compound 4 lay 1.3-fold (0.11 log units) below the measured number, within the range that was stated.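

In this assay, among these compounds, there is a 1.0-fold lower number from compound 3 to compound 4 (0.01 log units; within the scatter) as the first step of readable size, and it falls on the sulfur substituent itself. On a sulfur whose other neighbour is an aromatic carbon, exchanging isopropyl, with its 3 carbons and no ring, for cyclopentyl, with its 5 carbons in a five-membered ring, leaves the two numbers within the scatter of each other, so this pair gives no sign that the read-out responds to this change. The steps from compound 1 and from compound 2 to compound 4 cannot be read because compound 1 and compound 2 are reported only as limits of the assay and not as numbers: the limit of > 20000 nM in this assay, at which 2 of the 4 values shown sit.

Among the compounds shown here, only two groups on sulfur carry true numbers here, so whether the same reading would hold for a smaller methyl group or for an aromatic phenyl ring on that sulfur stays open. Also open, from the compounds shown here alone, is where compound 1 and compound 2 truly lie relative to the two sulfur compounds, and so whether the methylamino or 2,2,2-trifluoroethoxy groups differ from them at all in this read-out.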